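From (oxiran-2-yl)methoxy to 3-chloro-2-hydroxypropoxy

The compounds below may be only part of what the source reports. "The series", "measured", "known", "first", "only" and "open" are said of these compounds alone.

Measured so far in a functional assay on DU-145 cells (Homo sapiens) for cytotoxicity, read by MTT assay (a higher number here means a weaker inhibitor, a lower number a stronger inhibitor), are three compounds:
Compound 1 `COc1ccc(/C=C/C(=O)c2ccc(OCC3CO3)cc2)cc1` gives 43300 nM as a number
Compound 2 `O=C(/C=C/c1ccc(OCC2CO2)cc1)c1ccc(OCC2CO2)cc1` gives > 50000 nM as a limit
Compound 3 `COc1ccc(C(=O)/C=C/c2ccc(OCC(O)CCl)cc2)cc1` gives > 50000 nM as a limit

Compound 1 is the only one of the three with a number. Compound 2 and compound 3 offer only the limit of > 50000 nM in this assay, at which 2 of the 3 values shown sit, and nothing finer.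

Next in line is compound 4 `COc1ccc(/C=C/C(=O)c2ccc(OCC(O)CCl)cc2)cc1` with 2-chloro-1-hydroxyethyl in place of oxiran-2-yl on a saturated chain carbon bound to an oxygen on an aromatic ring. The change is 2-chloro-1-hydroxyethyl in place of oxiran-2-yl on a saturated chain carbon bound to an oxygen on an aromatic ring and reads in full as (oxiran-2-yl)methoxy to 3-chloro-2-hydroxypropoxy.

For the measured compounds named here, the one measured step, an at least 1.1-fold higher number from compound 1 to compound 2 (0.06 log units; that floor lies within the scatter), adds a second oxiran-2-yl and leaves the group in question in place, so it bears on this change only indirectly. Compound 3 already carries 3-chloro-2-hydroxypropoxy on an altered core, and its reading of > 50000 nM is a limit. Going by the values given here, no step directly links compound 3 to compound 4.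

On this basis no step beyond the scatter is expected in this assay, with any drift towards a higher number. The expected step is a 1.2-fold higher number from compound 1 to compound 4 (0.06 log units; within the scatter) and a reading at the limit would be no surprise. The estimate for compound 4 is 50000 nM with an expected range of 25000 nM to 90000 nM in this assay.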

Compound 4, half-maximal inhibitory concentration: > 50000 nM
Compound 4 was reported as a limit (the forecaster's own chance of this, stated with the estimate: 60%); the middle value sits exactly at the limit.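

In this assay compound 4 is reported only as a limit, > 50000 nM. For the compounds shown here, with 2-chloro-1-hydroxyethyl in place of oxiran-2-yl on a saturated chain carbon bound to an oxygen on an aromatic ring, the shared core gives the first direct reading of this change, an at least 1.1-fold higher number from compound 1 to compound 4 (0.06 log units; that floor lies within the scatter), so the floor of the step gives no evidence of a shift beyond the scatter, while its true size stays unknown. Compound 1 thus remains the only compound with a number, and the ring-free group gives no sign of a lower number, which leaves little range for reading this position: the limit of > 50000 nM in this assay, at which 3 of the 4 values shown sit.

On these data alone, how far compound 4 actually lies from compound 1 stays open, as does the question of whether this position can give a clearly lower number at all. Also open, as far as these compounds go, is whether an amine or a carboxylic acid at the end of the chain, or a longer chain in place of 2-chloro-1-hydroxyethyl, would bring the reading in this assay down from the limit to a measurable number.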